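The compounds below may be only part of what the source reports. "The series", "measured", "known", "first", "only" and "open" are said of these compounds alone.

Measured so far:
compound 1 `COc1ccc(-c2ccoc2-c2cc(OC)c(OC)c(OC)c2)cc1O` gives 3.1 nM
compound 2 `COc1ccc(-c2cscc2-c2cc(OC)c(OC)c(OC)c2)cc1` gives 420 nM
compound 3 `COc1cccc(-c2cscc2-c2cc(OC)c(OC)c(OC)c2)c1F` gives 430 nM

All three were run in a functional assay on HeLa cells (Homo sapiens) for cytotoxicity, read by MTT assay, with a stated time of 48 h; a higher number here means a weaker inhibitor, a lower number a stronger inhibitor. Among the measured compounds shown here, compound 1 holds the lowest number of the three; compound 2 and compound 3 sit far higher, each beyond the scatter from compound 1, and each carries a different core from compound 1, so no single-change step is available. Compound 4 `COc1ccc(-c2ccoc2-c2cc(OC)c(OC)c(OC)c2)cc1` keeps the core of compound 1 and differs from it in one place: hydrogen in place of hydroxy on an aromatic carbon. Nothing measured isolates this change; compound 2 also lacks the hydroxy, but on another core. In this assay the change is expected to raise the number by a moderate amount, likely beyond the scatter. Compound 4 is expected at 15 nM with a range of 3 nM to 100 nM. The step of a 4.8-fold higher number from compound 1 to compound 4 (0.68 log units; beyond the scatter) is thus an expected loss.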

Compound 4, half-maximal inhibitory concentration: 17 nM
Compound 4: middle estimate off by 1.1-fold (0.05 log units), on the low side; measured number inside the range.
By their numbers in this assay, from the lowest: compound 1; then compound 4; then compounds 2 and 3 (each within the scatter of the next).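

Hydrogen in place of hydroxy on this aromatic carbon, ortho to a methoxy group, gives a 5.5-fold higher number from compound 1 to compound 4 (0.74 log units; beyond the scatter) in this assay; this is the first single-change reading at this position. The hydroxy thus accounts for part of the low number on this core, yet without it compound 4 still gives 17 nM. Nothing on hand accounts for the size of this step.

Still open, on these data alone, is how an amine or a carboxylic acid on this carbon would read against hydroxy and hydrogen. The compounds shown also leave open whether the same change costs as much on a different core.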